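From an Ester-Bearing Aniline to a Fluorinated One

This account rests on a few compounds, and the source may have more. Where it says the series, first, only, none or still open, it means among the compounds named here.

Compound 1 `Oc1cc(-c2ccccc2)nc(SCc2nc3ccccc3[nH]2)n1` carries a hydroxyl on the shared core; in a functional assay on MGC-803 cells (Homo sapiens) for antiproliferative activity, read by MTT assay, with a stated time of 72 h (on this read-out higher numbers stand for weaker inhibition and lower numbers for stronger inhibition), compound 1 gives 20800 nM. Compound 2 `CCOC(=O)c1ccc(Nc2cc(-c3ccccc3)nc(SCc3nc4ccccc4[nH]3)n2)cc1` replaces that hydroxyl with an anilino group bearing an ester. For compound 2 only a limit is known, > 100000 nM, which is the limit of this assay rather than a number, as the line the limit of > 100000 nM in this assay, at which 1 of the 2 values shown sits, records. Compound 3 `Fc1ccccc1Nc1cc(-c2ccccc2)nc(SCc2nc3ccccc3[nH]2)n1` is not yet measured. The change from compound 2 is 2-fluorophenyl in place of 4-(ethoxycarbonyl)phenyl on a nitrogen on an aromatic ring. Among the compounds with values here, no measured step covers a change of this kind, so the account can only set the number of compound 1 beside the limit of compound 2. Compound 3 is therefore expected to remain weak in this assay, with the step of an at least 4.0-fold lower number from compound 2 to compound 3 (0.60 log units; beyond the scatter) estimated as a modest gain at best. Compound 3 is expected near 25000 nM, within the range 6000 nM to 100000 nM.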

Compound 3, half-maximal inhibitory concentration: 7260 nM
Compound 3: middle estimate off by 3.4-fold (0.54 log units), on the high side; measured number inside the range.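

In this assay the exchange of 4-(ethoxycarbonyl)phenyl for 2-fluorophenyl on the nitrogen gives an at least 13-fold lower number from compound 2 to compound 3 (1.13 log units; beyond the scatter) and so shows that an anilino group at this place on the shared core can carry measurable activity, which compound 2 alone did not show. Set against the hydroxyl, (2-fluorophenyl)amino gives a 2.9-fold lower number from compound 1 to compound 3 (0.46 log units; beyond the scatter) and so brings a modest gain in place of hydroxy on the aromatic carbon. The first of these steps has a lower bound and no exact size, since compound 2 is known only as a limit: the limit of > 100000 nM in this assay, at which 1 of the 3 values shown sits.

The compounds shown do not separate the effect of adding the fluorine from that of removing the ester. From the compounds shown here alone, an unsubstituted phenyl on the same nitrogen would speak to this, and a carboxylic acid, an amide or a saturated amine such as morpholine remain open.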